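Removing the aromatic methyl: compound 1 to compound 3

The source may report more compounds than this note shows. Statements on the series, on what has been measured and on what is new or still open speak of the compounds shown alone.

Of the compounds shown here, two have so far been measured in an assay for inhibition of Polyunsaturated fatty acid 5-lipoxygenase (Homo sapiens), read by HPLC, with stated times of 15 min and 10 min; a lower number here means a stronger inhibitor, a higher number a weaker inhibitor. Compound 1 `Cc1ccc(C(=O)NCc2ccccc2C(F)(F)F)cc1C#CC(C)N(O)C(N)=O` gives 1700 nM in this assay. Compound 2 `CC(C#Cc1ccc(C(=O)NCc2ccccc2C(F)(F)F)o1)N(O)C(N)=O` gives 4000 nM in this assay. Compound 1 stands at the lowest of the two numbers, and the gap to compound 2 lies beyond the scatter. For the measured compounds named here, no pair of measured compounds differs in only one place, so no measured single step is at hand to lean on.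

Compound 3 `CC(C#Cc1cccc(C(=O)NCc2ccccc2C(F)(F)F)c1)N(O)C(N)=O` has not yet been measured. It differs from compound 1 by hydrogen in place of methyl on an aromatic carbon. Going by the values given here, nothing among the measured compounds speaks directly to a hydrogen in place of methyl on an aromatic carbon. The step from compound 1 to compound 3 is expected to be a 1.3-fold higher number from compound 1 to compound 3 (0.11 log units; within the scatter), small and not clearly beyond the scatter, leaning toward a weaker number. Compound 3 is therefore estimated at about 2200 nM in this assay, with a range from 900 nM to 5500 nM.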

Compound 3, half-maximal inhibitory concentration: 700 nM
Compound 3: middle estimate off by 3.1-fold (0.50 log units), on the high side; measured number below the stated range.
By their numbers in this assay, from the lowest: compound 3; then compound 1; then compound 2.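

Notes on the aromatic methyl: this is the first single-place comparison in the series. On the aromatic carbon ortho to the 3-(carbamoyl(hydroxy)amino)but-1-yn-1-yl group and para to a large group, hydrogen in place of methyl in this assay gives a 2.4-fold lower number from compound 1 to compound 3 (0.39 log units; beyond the scatter) and so shows that the methyl is not required for inhibition here and that its loss brings a gain beyond the scatter. No measurement at hand accounts for this step.

From the compounds shown here alone, whether a chlorine atom, a methoxy group or a longer chain such as ethyl on this carbon would track with methyl or with hydrogen remains open, as a single step fixes no trend across substituents. Also open, going by these compounds, is whether the same gain would appear on a core other than that of compound 1.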